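A few compounds are considered here, and "the series" means these few. Any claim that something is new, unique, unknown or untested is made for them only; others in the source may bear on it.

Measured compounds:
- compound 1 `COc1ccccc1N1CCN(Cn2nc(-c3ccncc3)oc2=S)CC1`: > 250000 nM
- compound 2 `S=c1oc(-c2ccncc2)nn1CN1CCN(c2ccccn2)CC1`: "not determined" (no result reported)

In an ADME assay on MCF7 cells (Homo sapiens) for cytotoxicity, read by MTT assay, with a stated time of 48 h (on this read-out lower numbers stand for stronger inhibition and higher numbers for weaker inhibition), compound 1 gives > 250000 nM, which is a limit of the assay rather than a number. For compound 2, this assay reports "not determined" (no result reported). For the measured compounds named here, compound 2 therefore stands on no number of its own, and the one other value shown is the limit of > 250000 nM in this assay, at which 1 of the 2 values shown sits.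

Compound 3 `CCN1CCN(Cn2nc(-c3ccncc3)oc2=S)CC1` has not yet been measured. It differs from compound 2 by ethyl in place of pyridin-2-yl on an amine nitrogen in a ring. Going by the values given here, no step between measured compounds is known, so the size and direction of the move from compound 2 to compound 3 in this assay cannot be read from any measured pair. No step beyond the usual scatter is expected, and the only anchor available is that compound 1 sits at the limit of > 250000 nM in this assay, at which 1 of the 2 values shown sits. Compound 3 is therefore expected to come out near 200000 nM, with a range from 50000 nM to 500000 nM, and with a good chance that only a limit and no number is reported.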

Compound 3, half-maximal inhibitory concentration: > 250000 nM
Compound 3 ended at the assay's limit (the forecaster's own chance of this, stated with the estimate: 70%); middle value at least 1.2-fold (0.09 log units) away from the limit.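

No new step can be read: in this assay, compound 1 and compound 3 both end at a limit rather than a number, so the change from 2-methoxyphenyl to ethyl has no readable size. The compounds shown leave open how strongly any of them acts and whether the group on this amine nitrogen matters, with most values at one limit: the limit of > 250000 nM in this assay, at which 2 of the 3 values shown sit.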